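The source may hold more compounds than are shown below. What is called first, only, known or untested is meant among the compounds shown, and "the series" means these compounds.

In a functional assay on HCT-116 cells (Homo sapiens) for antiproliferative activity, read by MTT assay, with a stated time of 72 h (on this read-out higher numbers stand for weaker inhibition and lower numbers for stronger inhibition), compound 1 `O=C(CCc1cccc2c1B(O)OC2)Nc1ccccc1` gives 350 nM and compound 2 `O=C(CCc1cccc2c1B(O)OC2)Nc1cccc(I)c1` gives 2300 nM while compound 3 `O=C(CCc1cccc2c1B(O)OC2)Nc1cccc(-c2ccc(OC(F)(F)F)cc2)c1` gives 730 nM and so stands in the middle of the three numbers, with compound 1 lower and compound 2 higher. Compound 4 `N#Cc1ccc(-c2cccc(NC(=O)CCc3cccc4c3B(O)OC4)c2)cc1` differs from compound 3 in one place, with cyano in place of trifluoromethoxy on an aromatic carbon, para to a large group (the change in full: cyano in place of trifluoromethoxy on an aromatic carbon). Among the compounds with values here, the only measured step between compounds that differ in one place is a 6.6-fold higher number from compound 1 to compound 2 (0.82 log units; beyond the scatter) for iodo in place of hydrogen on an aromatic carbon. That modest step shows that a single group can move the number beyond the scatter, but it concerns a different exchange and gives no direction here. Within the data shown here, no measured step exchanges cyano or trifluoromethoxy. In this assay no shift beyond the scatter is expected, and the estimated step stays small at a 1.1-fold lower number from compound 3 to compound 4 (0.05 log units; within the scatter) only. For compound 4 the estimated value is 650 nM with 250 nM to 1700 nM as the expected range.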

Compound 4, half-maximal inhibitory concentration: 410 nM
For compound 4 the middle estimate is 1.6-fold (0.20 log units) above the measured one, within the range that was stated.
By their numbers in this assay, from the lowest: compounds 1, 4 and 3 (each within the scatter of the next, the first and the last beyond it); then compound 2.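

In this assay cyano in place of trifluoromethoxy, on an aromatic carbon para to a large group, gives a 1.8-fold lower number from compound 3 to compound 4 (0.25 log units; within the scatter) and so the two groups cannot be told apart here, even though cyano has fewer heavy atoms. 4-Cyanophenyl in place of iodo gives a 5.6-fold lower number from compound 2 to compound 4 (0.75 log units; beyond the scatter) while 4-cyanophenyl in place of hydrogen gives a 1.2-fold higher number from compound 1 to compound 4 (0.07 log units; within the scatter) and so this whole added ring stays within the scatter of the unsubstituted compound, which iodo did not. Nothing measured here accounts for why these groups give these numbers.

On these data alone, whether an amine, a carboxylic acid or a longer chain in place of cyano would keep the number at this level stays open. With so few groups at this place, it is also unclear how much variety it tolerates.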